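Shifting the aryl substituent on the shared amine

The compounds below may be only part of what the source reports. "The series", "measured", "known", "first", "only" and "open" are said of these compounds alone.

Measured so far:
compound 1 `CCc1ccc(NC2=CC(=O)c3nc4n(c3C2=O)[C@H]2OC[C@@H](O)[C@H]2OC4)cc1` — 3990 nM
compound 2 `CCOc1ccc(NC2=CC(=O)c3c(nc4n3[C@H]3OC[C@@H](O)[C@H]3OC4)C2=O)cc1` — 14400 nM
compound 3 `CCOc1ccccc1NC1=CC(=O)c2c(nc3n2[C@H]2OC[C@@H](O)[C@H]2OC3)C1=O` — 8300 nM

In a functional assay on HeLa cells (Homo sapiens) for inhibition, read by sulforhodamine B assay (on this read-out higher numbers stand for weaker inhibition and lower numbers for stronger inhibition), compound 1 gives 3990 nM, the lowest of the three numbers and thus the strongest inhibitor in this set, as both other compounds lie beyond the scatter above it. Compound 4 `COc1cccc(NC2=CC(=O)c3nc4n(c3C2=O)[C@H]2OC[C@@H](O)[C@H]2OC4)c1` is not yet measured. It differs from compound 1 in one place: 3-methoxyphenyl in place of 4-ethylphenyl on an amine nitrogen.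

For the measured compounds named here, one measured step bears on it. The exchange of 4-ethoxyphenyl for 2-ethoxyphenyl, a 1.7-fold lower number from compound 2 to compound 3 (0.24 log units; within the scatter), left the number essentially unchanged, so a change in where the substituent sits on the phenyl ring seems to matter little. What the values of compound 1 and compound 2 show is that an ethoxy group in place of an ethyl group goes with a clearly higher number. Since compound 4 carries a methoxy group rather than an ethyl group, a moderately higher number is expected, a 2.0-fold higher number from compound 1 to compound 4 (0.30 log units; within the scatter). Compound 4 is therefore estimated at 8000 nM, within a range of 3000 nM to 22000 nM.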

Compound 4, half-maximal inhibitory concentration: 4280 nM
Compound 4: the middle estimate sits 1.9-fold (0.27 log units) above what was measured; the measured number falls inside the stated range.
By their numbers in this assay, from the lowest: compounds 1, 4, 3 and 2 (each within the scatter of the next, the first and the last beyond it).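

In this assay, the step of a 1.1-fold higher number from compound 1 to compound 4 (0.03 log units; within the scatter) shows that this amine substituent can change in two ways at once without a reading change beyond the scatter: the ring substituent differs, and so does its place on the phenyl ring. The entering 3-methoxyphenyl group brings an oxygen and a hydrogen-bond acceptor, while the heavy-atom count stays the same, so in this pair the oxygen does not go with weaker inhibition. No measurement given here explains why the two compounds read alike.

Because both features change together, this pair cannot separate the effect of swapping ethyl for methoxy from that of moving the substituent. It also leaves open whether the shared core would tolerate a phenyl ring carrying an amine, a carboxylic acid or a longer alkyl chain on this nitrogen.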